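This account rests on a few compounds, and the source may have more. Where it says the series, first, only, none or still open, it means among the compounds named here.

Read-out: an ADME assay on microsomes from liver (Rattus norvegicus) for metabolic stability, with a stated time of 60 min, tested at 1 uM; a lower number here means that less of the compound is left, a higher number that more of the compound is left
- compound 1 `COc1cc(-c2cnn3cc(OC)c(C(C)C)nc23)ccn1` gives 14%
- compound 2 `COc1cc(-c2cnn3cc(OC)c([C@@H]4COC(C)(C)C4)nc23)ccn1` gives 30%

Compound 2 holds the higher of the two numbers, with 30% as the reference for the next change. Going to compound 3 `COc1cc(-c2cnn3cc(OC)c(C4CCCC4)nc23)ccn1` means a group of 5 heavy atoms (5 carbon; one five-membered non-aromatic ring of carbon only) in place of a group of 7 heavy atoms (6 carbon, 1 oxygen; one five-membered non-aromatic ring with 1 hetero atom), on an aromatic carbon on the shared core. Among the compounds with values here, the only measured step that bears on this is a number 16 percentage points higher from compound 1 to compound 2 (beyond the scatter) and it is modest. Cyclopentyl holds carbon only, as does the group in compound 1, so compound 3 is expected to fall back towards compound 1 (14%) in this assay. The expected downward move is a number 16 percentage points lower from compound 2 to compound 3 (beyond the scatter) and it would undo that gain. Compound 3 is estimated at 14% with an expected range from 5% to 28% in this assay.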

Compound 3, percent of the compound remaining: 7%
For compound 3 the middle estimate is 7 percentage points above the measured one, within the range that was stated.
By their numbers in this assay, from the lowest: compounds 3 and 1 (each within the scatter of the next); then compound 2.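

Replacing the oxygen-bearing ring with cyclopentyl gives a number 23 percentage points lower from compound 2 to compound 3 (beyond the scatter) in this assay and the carbon-only ring does not hold the higher number. Replacing isopropyl with cyclopentyl gives a number 7 percentage points lower from compound 1 to compound 3 (within the scatter) so the larger carbon-only group makes no readable difference at this position. The higher number goes with the ring of compound 2 rather than with ring size alone. No measurement here explains this difference. On these data alone, it remains open whether the ring oxygen or the two methyl groups carry it, and how a pyrrolidine or tetrahydropyran ring would read.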